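This account rests on a few compounds, and the source may have more. Where it says the series, first, only, none or still open, it means among the compounds named here.

Measured so far in a functional assay on HeLa cells (Homo sapiens) for antiproliferative activity, read by MTT assay, with a stated time of 48 h; a higher number here means a weaker inhibitor, a lower number a stronger inhibitor:
- compound 1 `Cn1cc(-c2cnc3ccc(NC(=O)c4cccnc4)nc3c2)cn1`: > 50000 nM (a limit)
- compound 2 `CCNc1ccc2ncc(-c3cnn(C)c3)cc2n1`: > 50000 nM (a limit)

Compound 2 has no number, only the limit > 50000 nM. The other compound shares this position, as the limit of > 50000 nM in this assay, at which 2 of the 2 values shown sit, records. Compound 3 `Cn1cc(-c2cnc3ccc(NCc4ccc(F)cc4)nc3c2)cn1` changes the ethyl of compound 2 to 4-fluorobenzyl: 4-fluorophenyl in place of methyl on a saturated chain carbon bound to a nitrogen on an aromatic ring. That is 4-fluorophenyl in place of methyl on a saturated chain carbon bound to a nitrogen on an aromatic ring. Within the data shown here, the only measured step is a step that the two limits leave unreadable from compound 1 to compound 2, so it offers no size to carry over. No step beyond the scatter is therefore expected in this assay, although a modest move towards stronger inhibition cannot be excluded. The estimated result is an at least 1.2-fold lower number from compound 2 to compound 3 (0.09 log units; that floor lies within the scatter). Compound 3 is expected at 40000 nM, with an estimated range of 15000 nM to 80000 nM.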

Compound 3, half-maximal inhibitory concentration: 46600 nM
Estimate against measurement, compound 3: 1.2-fold (0.07 log units) below; measured number inside the range.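

In this assay, among these compounds, compound 3 gives 46600 nM, the first number at this position rather than a limit. The change of ethyl to 4-fluorobenzyl gives an at least 1.0-fold lower number from compound 2 to compound 3 (0.03 log units; that floor lies within the scatter), and 4-fluorobenzyl in place of (pyridin-3-yl)carbonyl gives an at least 1.0-fold lower number from compound 1 to compound 3 (0.03 log units; that floor lies within the scatter); both floors lie within the scatter, so neither step shows a real difference, and the step between the two earlier compounds cannot be read. Only limits stand for the other two compounds: the limit of > 50000 nM in this assay, at which 2 of the 3 values shown sit.

From the compounds shown here alone, whether a longer chain such as phenethyl, or a 4-aminobenzyl group in place of 4-fluorobenzyl, would move the number beyond the scatter stays open. Also open, going by these compounds, is what numbers compound 1 and compound 2 would take, so the true size of both steps remains unknown.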